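Notes on a hydrazone series: acyl change toward compound 4

The source may hold more compounds than are shown below. What is called first, only, known or untested is meant among the compounds shown, and "the series" means these compounds.

Measured compounds:
- compound 1 `CNc1nc(C)c(C(=O)N/N=C/c2ccccc2C(F)(F)F)s1`: in a functional assay on MCF7 cells (Homo sapiens) for inhibition, read by MTT assay, with a stated time of 72 h (on this read-out higher numbers stand for weaker inhibition and lower numbers for stronger inhibition), compound 1 gives > 100 ug/mL, which is a limit of the assay and not a number.
- compound 2 `CN(C(=O)NC(=O)c1cccc(C(F)(F)F)c1)c1nc(C(F)(F)F)c(C(=O)N/N=C/c2ccc(C(F)(F)F)cc2)s1`: compound 2 gives 6.5 ug/mL.
- compound 3 `CN(C(=O)NC(=O)c1cccc(C(F)(F)F)c1)c1nc(C(F)(F)F)c(C(=O)N/N=C/c2ccccc2C(F)(F)F)s1`: compound 3 gives 7.69 ug/mL.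

Compound 3 holds the highest of the two numbers, with compound 2 nearest: a 1.2-fold higher number from compound 2 to compound 3 (0.07 log units; within the scatter). Compound 1 sits at the limit of > 100 ug/mL in this assay, at which 1 of the 3 values shown sits, and gives no number to compare.

Compound 4 `CN(C(=O)NC(=O)c1c(Cl)cccc1Cl)c1nc(C(F)(F)F)c(C(=O)N/N=C/c2ccccc2C(F)(F)F)s1` differs from compound 3 at the other end of the molecule: 2,6-dichlorophenyl in place of 3-(trifluoromethyl)phenyl on a carbonyl carbon. Within the data shown here, no measured step touches the carbonyl-bound aryl group, so nothing measured bears directly on this change. Among the measured compounds shown here, the only measured step between numbered compounds, a 1.2-fold higher number from compound 2 to compound 3 (0.07 log units; within the scatter), lies at the carbon with a double bond to nitrogen and stays within the scatter. For the measured compounds named here, with no measured precedent at the acyl position, the expectation for compound 4 is a step of no particular direction beyond the scatter: a 1.0-fold higher number from compound 3 to compound 4 (0.02 log units; within the scatter). Compound 4 is therefore estimated at 8 ug/mL, with a range from 3 ug/mL to 22 ug/mL.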

Compound 4, half-maximal inhibitory concentration: 6.24 ug/mL
Compound 4: middle estimate off by 1.3-fold (0.11 log units), on the high side, and the stated range covers the measured number.
By their numbers in this assay, from the lowest: compounds 4, 2 and 3 (each within the scatter of the next). At a limit, above all of these: compound 1.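

In this assay the carbonyl-bound aryl group now has its first measured step: a 1.2-fold lower number from compound 3 to compound 4 (0.09 log units; within the scatter), so 2,6-dichlorophenyl in place of 3-(trifluoromethyl)phenyl on a carbonyl carbon does not move the number beyond the scatter. With the step at the other end of the molecule, a 1.2-fold higher number from compound 2 to compound 3 (0.07 log units; within the scatter), both aryl changes shown so far stay within the scatter, so neither position has yet been shown to set the read-out. Nothing at hand gives a cause for the size of this step.

As far as these compounds go, only halogen-bearing aryl groups appear on this carbonyl carbon, so an unsubstituted phenyl, a methoxyphenyl, an alkyl chain or an aliphatic amine there remains open. Compound 1 gives > 100 ug/mL, which is a limit and not a number, and it differs from compound 3 in more than one place, so that gap stays unassigned.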